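The compounds below may be only part of what the source reports. "The series", "measured", "known", "first", "only" and "open" are said of these compounds alone.

Of the compounds shown here, three built on a shared core have been measured in a functional assay, with a stated time of 150 min; on this read-out higher numbers stand for weaker inhibition and lower numbers for stronger inhibition. Compound 1 `CCOC(=O)c1cnn(-c2nc(-c3ccccc3Cl)c(C#N)c(=O)n2C)c1N` gives 93 ug/mL in this assay. Compound 2 `CSc1nc(-c2cccc(O)c2O)c(C#N)c(=O)n1C` gives 53 ug/mL in this assay, and compound 3 `Cn1c(NN)nc(-c2ccccc2Cl)c(C#N)c1=O` gives 62 ug/mL. Compound 1 carries the highest of the three numbers, but its gaps to compound 3 and to compound 2 both lie within the usual scatter of repeated measurements, so the three compounds cannot be set in any order on this evidence.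

Compound 4 `CCOC(=O)c1cnn(-c2nc(-c3ccco3)c(C#N)c(=O)n2C)c1N` has not yet been measured in this assay. It differs from compound 1 in one place: furan-2-yl in place of 2-chlorophenyl on an aromatic carbon. Among the compounds with values here, no pair of measured compounds differs in only this way, so the effect of exchanging a six-membered aromatic ring of carbon only for a five-membered aromatic ring with one hetero atom cannot be read from the data. The step of a 1.0-fold lower number from compound 1 to compound 4 (0.01 log units; within the scatter) is therefore expected to be small, with no direction that can be told beyond the scatter. Compound 4 is estimated to give 90 ug/mL in this assay, within a range from 45 ug/mL to 180 ug/mL.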

Compound 4, half-maximal inhibitory concentration: 108 ug/mL
Estimate against measurement, compound 4: 1.2-fold (0.08 log units) below; low and high end bracket the measured number.
By their numbers in this assay, from the lowest: compounds 2, 3, 1 and 4 (each within the scatter of the next, the first and the last beyond it).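

In this assay, within the data shown here, the first pair of compounds differing in one place gives a 1.2-fold higher number from compound 1 to compound 4 (0.06 log units; within the scatter). At this aromatic carbon, ortho to a cyano group, furan-2-yl and 2-chlorophenyl therefore cannot be told apart on this read-out, although the exchange removes the chlorine and replaces a six-membered aromatic ring of carbon only with a five-membered aromatic ring with 1 hetero atom. No measurement offered here explains this outcome.

This single pair speaks only for these two aromatic groups on the core of compound 1. On these data alone, whether an amine, a carboxylic acid, a longer alkyl chain or a phenyl ring bearing hydroxyl groups at this position would give a step beyond the scatter remains open.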